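The compounds below may be only part of what the source reports. "The series", "measured", "known", "first", "only" and "open" are said of these compounds alone.

Among the compounds with values here, compound 2 `CC#CC(CC(=O)O)c1ccc(OCc2ccn3cc(-c4ccccc4)nc3c2)cc1` stands at the higher of the two numbers known so far: in an assay on isolated protein for agonist activity at Free fatty acid receptor 1 (Homo sapiens) (a lower number here means that less compound is needed, a higher number that more compound is needed for the effect), compound 2 gives 1260 nM, while compound 1 `CC#CC(CC(=O)O)c1ccc(OCc2ccc3nc(-c4ccc(CC)cc4)cn3c2)cc1` gives 496 nM, a gap beyond the usual scatter. Compound 3 `CC#CC(CC(=O)O)c1ccc(OCc2ccn3cc(-c4ccc(C(C)C)cc4)nc3c2)cc1` has not yet been measured. It differs from compound 2 in one place: isopropyl in place of hydrogen on an aromatic carbon, on the phenyl carried by the shared core. Within the data shown here, no measured pair shows this exact change, so its size is uncertain; a moderate gain in potency is expected, the step of a 2.5-fold lower number from compound 2 to compound 3 (0.40 log units; beyond the scatter) expressing that expectation. Compound 3 is accordingly estimated at 500 nM, with a range from 180 nM to 1400 nM.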

Compound 3, half-maximal effective concentration: 615 nM
Beside the measured number, compound 3's estimate is 1.2-fold (0.09 log units) below it; the range from low to high includes it.
By their numbers in this assay, from the lowest: compounds 1 and 3 (each within the scatter of the next); then compound 2.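

Going from phenyl to 4-isopropylphenyl on the shared core gives, in this assay, a 2.0-fold lower number from compound 2 to compound 3 (0.31 log units; beyond the scatter), the first direct reading of this position. A hydrogen on this aromatic carbon can thus give way to isopropyl with a modest gain in potency rather than a loss. Nothing available explains the size of this step. From the compounds shown here alone, whether a methyl group, a longer chain, a methoxy group or an amine at this place would give a similar step remains open. So does whether the same change would have the same effect on the core of compound 1.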